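A few compounds are considered here, and "the series" means these few. Any claim that something is new, unique, unknown or untested is made for them only; others in the source may bear on it.

Of the compounds shown here, three built on one shared core have been tested so far in a functional assay on DU-145 cells (Homo sapiens) for cytotoxicity, read by MTT assay; on this read-out higher numbers stand for weaker inhibition and lower numbers for stronger inhibition. There, compound 3 (`CCC(O)CO[C@H](CC=C(C)C)C1=CC(=O)c2c(O)ccc(O)c2C1=O`) gives 16400 nM and sits together with compound 1 (`CC(C)=CC[C@@H](OC[C@@H](C)O)C1=CC(=O)c2c(O)ccc(O)c2C1=O`) at 14300 nM on this scale. Compound 2 (`CCCCC(CC(=O)O[C@H](CC=C(C)C)C1=CC(=O)c2c(O)ccc(O)c2C1=O)OC(C)=O`) stands clearly higher at 67700 nM and so inhibits more weakly.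

Compound 4 (`CC(C)=CC[C@@H](OC(=O)CC(C)(O)C(C)C)C1=CC(=O)c2c(O)ccc(O)c2C1=O`) has not been measured yet. The structural change from compound 3 reads (2-hydroxy-2,3-dimethylbutyl)carbonyl in place of 2-hydroxybutyl on an oxygen on a saturated carbon and it turns 2-hydroxybutoxy into ((2-hydroxy-2,3-dimethylbutyl)carbonyl)oxy.

For the measured compounds named here, no measured step covers this change directly. The only one available, a 1.1-fold higher number from compound 1 to compound 3 (0.06 log units; within the scatter), shows that a small change in this chain stayed within the scatter. Going by the values given here, the better guide is compound 2 at 67700 nM as the only measured compound with a carbonyl on that oxygen, although one compound is thin support. A move towards weaker inhibition is therefore expected, an estimated 2.1-fold higher number from compound 3 to compound 4 (0.33 log units; beyond the scatter) in this assay. Compound 4 is expected at 35000 nM (estimated range 12000 nM to 90000 nM).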

Compound 4, half-maximal inhibitory concentration: 16900 nM
Compound 4: middle estimate off by 2.1-fold (0.32 log units), on the high side; the measured number falls inside the stated range.
By their numbers in this assay, from the lowest: compounds 1, 3 and 4 (each within the scatter of the next); then compound 2.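

In this assay, putting (2-hydroxy-2,3-dimethylbutyl)carbonyl in place of 2-hydroxybutyl on this oxygen leaves the number within the scatter (a 1.0-fold higher number from compound 3 to compound 4 (0.01 log units; within the scatter)), and the same holds against the 2-hydroxypropyl chain (a 1.2-fold higher number from compound 1 to compound 4 (0.07 log units; within the scatter)). A carbonyl on this oxygen therefore does not by itself go with weaker inhibition, even though compound 2 also carries one and is the weaker compound. What separates the two carbonyl compounds is the group on the saturated chain carbon bound to the carbonyl carbon, where 1-hydroxy-1,2-dimethylpropyl replaces 1-acetoxypentyl (a 4.0-fold lower number from compound 2 to compound 4 (0.60 log units; beyond the scatter)).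

No measurement shown explains why these chains behave as they do. Also open, going by these compounds, is how this position would respond to an amine or a carboxylic acid at the end of the chain, or to an unbranched longer chain that keeps its hydroxyl.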